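Trading the Diethylamide of Compound 2 for a Pyridyl Amide

A few compounds are considered here, and "the series" means these few. Any claim that something is new, unique, unknown or untested is made for them only; others in the source may bear on it.

Compound 1, `CCN(CC)C(=O)CN(c1cccc(N(C)C)c1C#N)S(=O)(=O)c1ccc(OC)c(OC)c1`: 110 nM
Compound 2, `CCN(CC)C(=O)CN(c1cc2c(C)nsc2cc1Cl)S(=O)(=O)c1ccc(OC)c(OC)c1`: 4.5 nM
Compound 3, `CCN(CC)C(=O)CN(c1cc(N(C)C)ccc1C#N)S(=O)(=O)c1ccc(OC)c(OC)c1`: 10 nM

In a functional assay on CHO cells for inhibition of Orexin receptor type 2 (Homo sapiens), read by FLIPR and calcium flux (on this read-out higher numbers stand for weaker inhibition and lower numbers for stronger inhibition), compound 2 gives the lowest of the three numbers: a 2.2-fold higher number from compound 2 to compound 3 (0.35 log units; beyond the scatter), and a 24-fold lower number from compound 1 to compound 2 (1.39 log units; beyond the scatter). Compound 4, `CCN(C(=O)CN(c1cc2c(C)nsc2cc1Cl)S(=O)(=O)c1ccc(OC)c(OC)c1)c1ccccn1`, differs from compound 2 by pyridin-2-yl in place of ethyl on an amide-type nitrogen. Every measured step, including an 11-fold lower number from compound 1 to compound 3 (1.04 log units; beyond the scatter), alters only the group on the sulfonamide nitrogen, so none of them speaks to a change at the amide-type nitrogen; the expectation rests on compound 2 alone. Compound 4 is therefore expected to stay near compound 2, a 1.3-fold higher number from compound 2 to compound 4 (0.12 log units; within the scatter), no more than the scatter. The estimate for compound 4 is 6 nM, in the range 1.5 nM to 25 nM.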

Compound 4, half-maximal inhibitory concentration: 5 nM
For compound 4 the middle estimate is 1.2-fold (0.08 log units) above the measured one; measured number inside the range.
By their numbers in this assay, from the lowest: compounds 2, 4 and 3 (each within the scatter of the next, the first and the last beyond it); then compound 1.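

With pyridin-2-yl in place of ethyl on the amide-type nitrogen, this assay gives a 1.1-fold higher number from compound 2 to compound 4 (0.05 log units; within the scatter). This is the first change shown at this nitrogen, and it shows that an aromatic ring with a hydrogen-bond acceptor can replace a saturated ethyl chain there with the number staying within the scatter. No measurement is available that would account for this result.

The compounds shown leave open what phenyl, a longer chain or an amine would give on this nitrogen. They also leave open whether the remaining ethyl can be replaced, and whether pyridin-2-yl behaves the same way with the sulfonamide nitrogen groups of compound 1 and compound 3.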